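The source may report more compounds than this note shows. Statements on the series, on what has been measured and on what is new or still open speak of the compounds shown alone.

Measured so far:
- compound 1, `Cc1nc(Nc2ccc(O)cc2)c2cc[nH]c2n1`: 155000000 nM
- compound 2, `CCC(C)Nc1[nH]c(C)nc2nccc1-2`: 174000000 nM
- compound 3, `C=CCNc1nc(C)nc2[nH]ccc12`: 676000000 nM

Three compounds share a core and differ in the group carried on the ring nitrogen. In a functional assay on the whole organism for inhibition, with Nicotiana tabacum as the target (a higher number here means a weaker inhibitor, a lower number a stronger inhibitor), compound 3 gives the highest number of the three, and its gaps to compound 2 and to compound 1 both lie beyond the usual scatter of the read-out. Going by the values given here, no two of the measured compounds differ in one place only, so no single step in this assay can be read from them directly.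

Compound 4, `Cc1nc(NCC2CC2)c2cc[nH]c2n1`, has not been measured. Compared with compound 3 the change is cyclopropyl in place of vinyl on a saturated chain carbon bound to a nitrogen on an aromatic ring. Among the compounds with values here, no measured pair shows this kind of change, so the expected step rests only on the spread of the three numbers, in which the one open-chain alkyl group, compound 2, sits lower than compound 3 in this assay.

The step from compound 3 to compound 4 is expected to be small, a modest drop in the number or none beyond the scatter, as a 1.7-fold lower number from compound 3 to compound 4 (0.23 log units; within the scatter). Compound 4 is estimated at 400000000 nM in this assay, with a range from 150000000 nM to 1200000000 nM.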

Compound 4, half-maximal inhibitory concentration: 77600000 nM
Beside the measured number, compound 4's estimate is 5.2-fold (0.71 log units) above it; the measured number lies below the stated range.
By their numbers in this assay, from the lowest: compounds 4, 1 and 2 (each within the scatter of the next, the first and the last beyond it); then compound 3.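

In this assay the series now has its first step that can be read at one place: cyclopropyl in place of vinyl on a saturated chain carbon bound to a nitrogen on an aromatic ring gives an 8.7-fold lower number from compound 3 to compound 4 (0.94 log units; beyond the scatter) and so lies beyond the scatter. This position therefore responds to an exchange between two groups of carbon only, neither carrying hydrogen-bond donors or acceptors, and the group that enters holds one more carbon and a three-membered ring in place of a double bond. Nothing at hand bears on the origin of this step.

Still open, on these data alone, is whether the ring, the loss of the double bond or the added carbon carries the step, which a plain propyl group at this place could help to separate. Also open, as far as these compounds go, is how the number responds to a larger ring, as in cyclobutylmethyl, or to an amine on the chain.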